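From 3,5-Dichlorophenyl to 3-Chloro-4-Fluorophenyl

A few compounds are considered here, and "the series" means these few. Any claim that something is new, unique, unknown or untested is made for them only; others in the source may bear on it.

When a compound is swallowed, only part of it reaches the blood, and that amount can shift with small changes in structure. In an ADME assay on the whole organism (Rattus norvegicus), with a stated time of 6 h, at a dose of 10 mg/kg by the oral route (a lower number here means less compound in the circulation, a higher number more compound in the circulation at the dose given), compound 1 (`N#Cc1cccc(-c2ccc(N(CCN3CCCC3)C(=O)Nc3ccc(C(F)(F)F)c(F)c3)cc2)c1`) gives 967 ng.h/mL and compound 2 (`N#Cc1cccc(-c2ccc(N(CCN3CC[C@@H](O)C3)C(=O)Nc3cc(Cl)cc(Cl)c3)cc2)c1`) gives 1850 ng.h/mL under the same conditions. Among the measured compounds shown here, these two values lie within the usual scatter of each other, so on the numbers so far compound 2 stands level with compound 1. The two compounds differ in more than one place, so their values do not show what any single change does.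

Compound 3 (`N#Cc1cccc(-c2ccc(N(CCN3CC[C@@H](O)C3)C(=O)Nc3ccc(F)c(Cl)c3)cc2)c1`) carries 3-chloro-4-fluorophenyl in place of 3,5-dichlorophenyl on an amide-type nitrogen and otherwise matches compound 2. For the measured compounds named here, no measured pair isolates this swap, so the expectation starts from compound 2 at 1850 ng.h/mL and allows a wide margin on both sides. The estimated change, a 1.2-fold lower number from compound 2 to compound 3 (0.09 log units; within the scatter), is expected to stay within the scatter, with no firm direction. In this assay the estimated value for compound 3 is 1500 ng.h/mL, within an expected range of 650 ng.h/mL to 3400 ng.h/mL for repeated measurements.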

Compound 3, area under the concentration-time curve: 1080 ng.h/mL
Compound 3: middle estimate off by 1.4-fold (0.14 log units), on the high side; low and high end bracket the measured number.
By their numbers in this assay, from the lowest: compounds 1, 3 and 2 (each within the scatter of the next).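

Putting 3-chloro-4-fluorophenyl in place of 3,5-dichlorophenyl on the amide-type nitrogen gives a 1.7-fold lower number from compound 2 to compound 3 (0.23 log units; within the scatter) in this assay, and this is the only pair shown that differs in one place. Both groups have the same count of heavy atoms and the same single aromatic ring of carbon, and neither has a hydrogen-bond donor or acceptor, so this exchange of one chlorine for a fluorine, with the halogens rearranged on the ring, cannot be told apart from repeat-measurement noise in this read-out. No measurement at hand bears on what lies behind this result.

Among the compounds shown here, compounds 2 and 3 cover only two halogen-bearing phenyl groups at this place, so it remains open how a plain phenyl, a methoxyphenyl or a phenyl carrying a carboxylic acid would behave in the same setting. Compound 1 differs from compound 2 and from compound 3 in more than one place, so its comparisons with them cannot be read as the effect of any single change.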